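The source may report more compounds than this note shows. Statements on the series, on what has been measured and on what is new or still open speak of the compounds shown alone.

Of the compounds shown here, three of a shared core have been measured in a functional assay on BGC-823 cells (Homo sapiens) for cytotoxicity, read by MTT assay, with a stated time of 72 h; a higher number here means a weaker inhibitor, a lower number a stronger inhibitor. Compound 1 `CN1[C@@H]2c3[nH]c4ccccc4c3C[C@H]1[C@H](C#N)N1[C@@H](CN3C(=O)c4ccccc4C3=O)c3[nH]c4ccccc4c3C[C@@H]21` gives 410 nM. Compound 2 `COc1ccc(C(=O)NC[C@H]2c3[nH]c4ccccc4c3C[C@H]3[C@H]4c5[nH]c6ccccc6c5C[C@@H]([C@H](C#N)N23)N4C)cc1` gives 320 nM, and the step of a 1.3-fold lower number from compound 1 to compound 2 (0.11 log units; within the scatter) changes little. Compound 3 `CN1[C@@H]2c3[nH]c4ccccc4c3C[C@H]1[C@H](C#N)N1[C@@H](CNC(=O)c3cccc4c3CCCC4)c3[nH]c4ccccc4c3C[C@@H]21` gives 3540 nM, which is the highest of the three numbers; the step of an 11-fold higher number from compound 2 to compound 3 (1.04 log units; beyond the scatter) is the one large move in the set, and compound 3 also stands well beyond the scatter from compound 1.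

Compound 4 `CN1[C@@H]2c3[nH]c4ccccc4c3C[C@H]1[C@H](C#N)N1[C@@H](CNC(=O)/C=C/c3cccc(C(F)(F)F)c3)c3[nH]c4ccccc4c3C[C@@H]21` is the next compound. It differs from compound 3 in one place: 2-(3-(trifluoromethyl)phenyl)ethenyl in place of 1,2,3,4-tetrahydronaphthalen-5-yl on a carbonyl carbon. Within the data shown here, no measured step swaps one aryl group on the amide carbonyl for an ethenyl-linked aryl group, so nothing bears on this exchange directly. What the set does show is that the group on this carbonyl can move the number a long way, as in the step from compound 2 to compound 3, while the step from compound 1 to compound 2 shows that a change of similar size can also leave the number unchanged. The expectation is that compound 4 lands between those two outcomes, with a modest move back toward the lower numbers of compound 1 and compound 2, as a 2.4-fold lower number from compound 3 to compound 4 (0.37 log units; beyond the scatter). In this assay compound 4 is therefore estimated at 1500 nM, within a range from 350 nM to 6000 nM.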

Compound 4, half-maximal inhibitory concentration: 910 nM
Compound 4: the middle estimate sits 1.6-fold (0.22 log units) above what was measured; the range from low to high includes it.
By their numbers in this assay, from the lowest: compounds 2 and 1 (each within the scatter of the next); then compound 4; then compound 3.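

In this assay, replacing 1,2,3,4-tetrahydronaphthalen-5-yl on the carbonyl carbon with 2-(3-(trifluoromethyl)phenyl)ethenyl gives a 3.9-fold lower number from compound 3 to compound 4 (0.59 log units; beyond the scatter), so the high number of compound 3 belongs to that particular group and not to every group that differs from 4-methoxyphenyl at this place. The recovery is only partial, however: the exchange of 4-methoxyphenyl for the same ethenyl-linked group gives a 2.8-fold higher number from compound 2 to compound 4 (0.45 log units; beyond the scatter), which means that the three groups on this amide carbonyl now give three numbers separated beyond the scatter, with compound 2 lowest, compound 4 in the middle and compound 3 highest. Nothing available explains why these groups rank in this order.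

Compound 4 brings in the ethenyl link and the trifluoromethyl group together, so the compounds shown cannot say how much of its step belongs to each; a plain 2-phenylethenyl group or a saturated 2-phenylethyl chain on the same carbonyl would begin to separate them. From the compounds shown here alone, it also remains open how this position responds to a group of a different kind, such as an aryl ring carrying an amine or a carboxylic acid.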